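Replacing Hydroxymethyl on Compound 3

This account rests on a few compounds, and the source may have more. Where it says the series, first, only, none or still open, it means among the compounds named here.

For the measured compounds named here, in a functional assay on NALM-6 cells (Homo sapiens) for cytotoxicity, with a stated time of 72 h (on this read-out lower numbers stand for an effect already at smaller amounts and higher numbers for an effect only at larger amounts of compound), compound 3 (`C=C[C@@](C)(/C=C/c1ccc(O)c(CO)c1)CCC=C(C)C`) gives 16400 nM, the only true number so far. Compound 1 (`C=C[C@@](C)(/C=C/c1ccc(O)cc1)CCC1OC1(C)C`) gives only a limit, > 43400 nM. Compound 2 (`C=C[C@@](C)(/C=C/c1ccc(O)cc1)CC/C=C(\C)CO`) also gives only a limit, > 43400 nM. Going by the values given here, the single measured step, a step that the two limits leave unreadable from compound 1 to compound 2, lies at a different place and offers no size to carry over.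

Compound 4 (`C=C[C@@](C)(/C=C/c1ccc(O)c(/C=C/C(=O)OCC)c1)CCC=C(C)C`) differs from compound 3 in one group: 2-(ethoxycarbonyl)ethenyl in place of hydroxymethyl on an aromatic carbon. Here 2-(ethoxycarbonyl)ethenyl stands in place of hydroxymethyl on an aromatic carbon, ortho to a hydroxy group. Among the compounds with values here, no measured step covers this change, so the reading of compound 3 at 16400 nM remains the only anchor, and no shift beyond the scatter is expected. The estimated change is a 1.3-fold lower number from compound 3 to compound 4 (0.10 log units; within the scatter). For compound 4 the estimate is 13000 nM, with an expected range from 4000 nM to 40000 nM.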

Compound 4, half-maximal effective concentration: 20900 nM
The estimate for compound 4 lay 1.6-fold (0.21 log units) below the measured number; low and high end bracket the measured number.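

In this assay, putting 2-(ethoxycarbonyl)ethenyl in place of hydroxymethyl ortho to a hydroxy group gives a 1.3-fold higher number from compound 3 to compound 4 (0.11 log units; within the scatter) and so leaves the reading within the scatter. For the compounds shown here, this aromatic carbon therefore tolerates a much larger group with no hydrogen-bond donor, a point the earlier compounds could not show. Nothing shown explains this outcome.

As far as these compounds go, whether an amine, a carboxylic acid or a longer chain at this carbon would shift the number remains open. The step between the two compounds that give only limits cannot be read.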